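From Bromo to Nitro at a Limit

This account rests on a few compounds, and the source may have more. Where it says the series, first, only, none or still open, it means among the compounds named here.

In a functional assay on A549 cells (Homo sapiens) for inhibition, read by MTT assay, with a stated time of 48 h (a lower number here means a stronger inhibitor, a higher number a weaker inhibitor), compound 1 (`CCCC(c1c[nH]c2ccc(Br)cc12)c1c[nH]c2ccc(Br)cc12`) gives 6500 nM. Compound 2 (`N#Cc1ccc2[nH]cc(C(c3ccc(Cl)cc3)c3c[nH]c4ccc(C#N)cc34)c2c1`) returns only a limit, > 100000 nM. Compound 3 (`N#Cc1ccc2[nH]cc(C(c3ccc(Br)cc3)c3c[nH]c4ccc(C#N)cc34)c2c1`) also returns only a limit, > 100000 nM. Compound 4 (`N#Cc1ccc2[nH]cc(C(c3ccc([N+](=O)[O-])cc3)c3c[nH]c4ccc(C#N)cc34)c2c1`) differs from compound 3 by nitro in place of bromo on an aromatic carbon. Among the measured compounds shown here, the one measured step at this place is a step that the two limits leave unreadable from compound 2 to compound 3, with bromo in place of chloro, so it offers no size to carry over. The nearest guide is the limit of > 100000 nM in this assay, at which 2 of the 3 values shown sit. No clear change in this assay is therefore expected, with an estimated a number no higher from compound 3 to compound 4 (the limit leaves the size open). Compound 4 is expected near 100000 nM, with an estimated range of 40000 nM to 200000 nM.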

Compound 4, half-maximal inhibitory concentration: > 100000 nM
Compound 4: only a limit was reported; the forecaster's own chance of this, stated with the estimate: 70%; the middle value sits exactly at the limit.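

Compound 4 gives only a limit, > 100000 nM, in this assay, so its steps from compound 2 and compound 3 cannot be read. The compounds shown leave open whether chloro, bromo and nitro differ at all in inhibition.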